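Working notes on a pyrazolopyridine series and the aryl-amidine swap

A few compounds are considered here, and "the series" means these few. Any claim that something is new, unique, unknown or untested is made for them only; others in the source may bear on it.

For the measured compounds named here, compound 1, `CCOC(=O)C1=C(N/C=N/c2cccnc2Cl)Nc2[nH]nc(C)c2C1c1ccc(N(C)C)cc1`, is the stronger of the two measured members. In a functional assay on HeLa cells (Homo sapiens) for inhibition, read by MTT assay, with a stated time of 48 h (on this read-out higher numbers stand for weaker inhibition and lower numbers for stronger inhibition), compound 1 gives 4630 nM, the lowest of the two numbers in hand. Compound 2, `CCOC(=O)C1=C(NN=C(C(C)=O)C(C)=O)Nc2[nH]nc(C)c2C1c1ccc(N(C)C)cc1`, replaces the 2-chloropyridin-3-yl amidine group on the amine nitrogen with an open-chain diketone hydrazone; in this assay compound 2 gives 17000 nM, and the step of a 3.7-fold higher number from compound 1 to compound 2 (0.56 log units; beyond the scatter) is modest but beyond the scatter.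

Compound 3, `CCOC(=O)C1=C(N/C=N/c2ccc(C)cc2)Nc2[nH]nc(C)c2C1c1ccc(N(C)C)cc1`, differs from compound 1 by 4-methylphenyl in place of 2-chloropyridin-3-yl on a double-bonded nitrogen. Going by the values given here, the only measured step, from compound 1 to compound 2, changes a different kind of group at that nitrogen, removing the ring altogether, and so bears only loosely on a ring-for-ring exchange; no measured pair shows what swapping one six-membered aromatic ring for another does here. The amidine linkage and the rest of the core are kept intact in compound 3, as in compound 1. With nothing in the data pointing either way, compound 3 is expected to sit near compound 1 in this assay, with a step of a 1.0-fold lower number from compound 1 to compound 3 (0.01 log units; within the scatter) that is not expected to exceed the scatter. Compound 3 is therefore estimated at 4500 nM, with a range from 1500 nM to 13000 nM.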

Compound 3, half-maximal inhibitory concentration: 43200 nM
Beside the measured number, compound 3's estimate is 9.6-fold (0.98 log units) below it; measured number above the stated range.
By their numbers in this assay, from the lowest: compound 1; then compound 2; then compound 3.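

In this assay, the ring on the double-bonded nitrogen cannot be exchanged freely, even when one six-membered aromatic ring replaces another: 4-methylphenyl in place of 2-chloropyridin-3-yl gives (a 9.3-fold higher number from compound 1 to compound 3 (0.97 log units; beyond the scatter)), a larger step than the one that removed the ring altogether in compound 2. Keeping the amidine linkage and an aromatic ring therefore does not by itself hold the number, and compound 3 also falls behind the open-chain diketone hydrazone of compound 2 (a 2.5-fold higher number from compound 2 to compound 3 (0.41 log units; beyond the scatter)). Nothing in hand gives a measured reason for this loss at the position.

The exchange changes the ring nitrogen, the chlorine and the methyl together, so the compounds shown leave open which of these changes carries the step, and whether any one of them does so alone. An unsubstituted phenyl, a 4-chlorophenyl or a plain pyridin-3-yl on the same double-bonded nitrogen, with the shared core unchanged, would divide the step into parts that can be read separately.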